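The source may report more compounds than this note shows. Statements on the series, on what has been measured and on what is new or still open speak of the compounds shown alone.

Compound 1 `COc1cc(/C=C/C(=O)OC/C=C/CO[N+](=O)[O-])ccc1O` gives 21900 nM in a functional assay on cells (Homo sapiens) for cytotoxicity, read by resazurin assay, with a stated time of 72 h; on this read-out higher numbers stand for weaker inhibition and lower numbers for stronger inhibition.
Compound 2 `O=C(/C=C/c1ccc(OCCCCCCO[N+](=O)[O-])c(O)c1)OCCCCCCO[N+](=O)[O-]` gives only a limit in this assay, > 50000 nM.

Compound 1 holds the only number shown. The other value, that of compound 2, is the limit of > 50000 nM in this assay, at which 1 of the 2 values shown sits. Compound 3 `COc1cc(/C=C/C(=O)OCCCO[N+](=O)[O-])ccc1O` differs from compound 1 by a group of 6 heavy atoms (2 carbon, 1 nitrogen, 3 oxygen; no ring) in place of a group of 7 heavy atoms (3 carbon, 1 nitrogen, 3 oxygen; no ring), on a saturated chain carbon bound to an oxygen next to a carbonyl group. No step between measured compounds is shown, so the expectation rests on the structures alone: with a group of 6 heavy atoms in place of a group of 7 heavy atoms, the expected step of a 1.0-fold higher number from compound 1 to compound 3 (0.00 log units; within the scatter) is none beyond the scatter. Compound 3 is therefore estimated at 22000 nM, between 8000 nM and 50000 nM.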

Compound 3, half-maximal inhibitory concentration: 39400 nM
The estimate for compound 3 lay 1.8-fold (0.25 log units) below the measured number; low and high end bracket the measured number.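

In this assay, for the compounds shown here, the change to 2-(nitrooxy)ethyl gives a 1.8-fold higher number from compound 1 to compound 3 (0.26 log units; within the scatter) on the saturated chain carbon bound to an oxygen next to a carbonyl group, the first step that can be read at this position. This exchange of one nitrooxy-bearing chain for another thus stays within the usual scatter. No measured result shown here explains this step.

From the compounds shown here alone, whether a longer chain or an amine at this position would move the number beyond the scatter remains open. So does the outcome of a hydroxyl group in place of the nitrooxy group.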